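Amide aryl swap in a cytotoxicity series

The compounds below may be only part of what the source reports. "The series", "measured", "known", "first", "only" and "open" are said of these compounds alone.

compound 1 `COc1ccc(C(=O)Nc2ccc(CCS(=O)(=O)/C=C/c3ccc(OC(C)=O)c(OC(C)=O)c3)cc2)cc1`: 858000 nM
compound 2 `CC(=O)Oc1ccc(/C=C/S(=O)(=O)CCc2ccc(NC(=O)c3cc(F)cc(F)c3)cc2)cc1OC(C)=O`: 225000 nM

Among the compounds with values here, in an ADME assay on TZM cells (Homo sapiens) for cytotoxicity, read by CCK-8 assay, with a stated time of 2 days (on this read-out higher numbers stand for lower toxicity in this test and lower numbers for higher toxicity in this test), compound 2 stands lowest of the two numbers; compound 1 sits higher by a 3.8-fold lower number from compound 1 to compound 2 (0.58 log units; beyond the scatter) read backwards, the only step known. Compound 3 `CC(=O)Oc1ccc(/C=C/S(=O)(=O)CCc2ccc(NC(=O)c3ccc(C)cc3)cc2)cc1OC(C)=O` differs from compound 2 by 4-methylphenyl in place of 3,5-difluorophenyl on a carbonyl carbon. Within the data shown here, the one step that bears on this, a 3.8-fold lower number from compound 1 to compound 2 (0.58 log units; beyond the scatter), concerns the same carbonyl carbon, where removing 3,5-difluorophenyl undoes a modest lowering; 4-methylphenyl is not 4-methoxyphenyl, so only part of that move is expected back. Compound 3 is therefore expected to show a 2.2-fold higher number from compound 2 to compound 3 (0.35 log units; beyond the scatter), toward a higher number. Compound 3 is estimated at 500000 nM, range 200000 nM to 1200000 nM.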

Compound 3, half-maximal cytotoxic concentration: 177000 nM
Compound 3: middle estimate off by 2.8-fold (0.45 log units), on the high side; measured number below the stated range.
By their numbers in this assay, from the lowest: compounds 3 and 2 (each within the scatter of the next); then compound 1.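

On the carbonyl carbon, 4-methylphenyl and 3,5-difluorophenyl cannot be told apart (a 1.3-fold lower number from compound 2 to compound 3 (0.10 log units; within the scatter)). Methyl in place of methoxy on an aromatic carbon gives a clearer separation (a 4.8-fold lower number from compound 1 to compound 3 (0.69 log units; beyond the scatter)), so among these three aryl groups only the 4-methoxyphenyl of compound 1 stands apart. Nothing available accounts for this difference.

On these data alone, whether the separation is specific to methoxy remains open. An ethoxy group, a longer alkoxy chain, or an amine in its place on the ring would test this.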